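The compounds below may be only part of what the source reports. "The series", "measured", "known", "first", "only" and "open" are said of these compounds alone.

Compound 1 `CCCCCOC(=O)CCC(=O)N1CCN(CCCOc2cc3c(Nc4ccc(F)c(Cl)c4)ncnc3cc2OC)CC1` gives 30% in a functional assay on A549 cells (Homo sapiens) for cytotoxicity, read by MTT assay, with a stated time of 24 h, tested at 60 uM; a higher number here means a weaker effect of the compound at the concentration tested, a lower number a stronger effect.
Compound 2 `CCCCCCCCCCCCOC(=O)CCC(=O)N1CCN(CCCOc2cc3c(Nc4ccc(F)c(Cl)c4)ncnc3cc2OC)CC1` gives 2% in this assay.
Compound 3 `CCCCCCCCCCCCCOC(=O)CCC(=O)N1CCN(CCCOc2cc3c(Nc4ccc(F)c(Cl)c4)ncnc3cc2OC)CC1` gives 20.6% in this assay.

Compound 3 thus sits with the second highest of the three numbers, close to compound 1 and within the scatter of it, while clearly apart from compound 2. Compound 4 `CCCCCCCCCCCCCCCCOC(=O)CCC(=O)N1CCN(CCCOc2cc3c(Nc4ccc(F)c(Cl)c4)ncnc3cc2OC)CC1` differs from compound 3 by propyl in place of hydrogen on a saturated chain carbon, ten or more bonds along the chain from an oxygen next to a carbonyl group. The step that bears on this change is a number 18.6 percentage points higher from compound 2 to compound 3 (beyond the scatter), an extension of the same chain at the same place, whereas the longer extensions a number 28 percentage points lower from compound 1 to compound 2 (beyond the scatter) and a number 9.4 percentage points lower from compound 1 to compound 3 (within the scatter) ran the other way. No consistent direction emerges, so the expected step of a number 4.6 percentage points lower from compound 3 to compound 4 (within the scatter) is none beyond the scatter. Compound 4 is estimated at 16%, with a range from 2% to 32%.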

Compound 4, a percentage reported as activity, at one concentration (the size of the read-out at that concentration, not a potency): 80%
Compound 4: the middle estimate sits 64 percentage points below what was measured, and the stated range ends below it.
By their numbers in this assay, from the lowest: compound 2; then compounds 3 and 1 (each within the scatter of the next); then compound 4.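

In this assay, propyl in place of hydrogen on this chain brings a number 59.4 percentage points higher from compound 3 to compound 4 (beyond the scatter), the first large step among these compounds. The same holds against the shorter chains, with a number 78 percentage points higher from compound 2 to compound 4 (beyond the scatter) and a number 50 percentage points higher from compound 1 to compound 4 (beyond the scatter), so compound 4 has the weakest effect at the concentration tested and the longest chain shown stands apart from the other three. Nothing available accounts for this jump.

From the compounds shown here alone, whether a still longer chain would keep the number this high remains open. So does the effect of an amine or a carboxylic acid on this chain.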